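The compounds below may be only part of what the source reports. "The series", "measured", "known", "first", "only" and "open" are said of these compounds alone.

Compound 1, `NC(=O)c1ccc(NC2=CC(=O)c3ncncc3C2=O)cc1`, carries a carbamoyl group on the aniline ring that hangs from the shared core. In a functional assay on PANC-1 cells (Homo sapiens) for cytotoxicity, read by MTT assay, with a stated time of 72 h (on this read-out lower numbers stand for stronger inhibition and higher numbers for weaker inhibition), compound 1 gives 6300 nM. Among the measured compounds shown here, its only measured companion is compound 2, `COc1cccc(NC2=CC(=O)c3ncncc3C2=O)c1`, which bears a methoxy group instead; in this assay compound 2 gives 600 nM. Of these two numbers compound 1 holds the higher one, and the gap between them lies beyond the usual scatter, so compound 1 is the weaker inhibitor of the pair.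

The next compound, compound 3, `CCOC(=O)c1ccc(NC2=CC(=O)c3ncncc3C2=O)cc1`, keeps the whole skeleton of compound 1 and alters only the carbonyl carbon on the aniline ring: ethoxy in place of amino on a carbonyl carbon. For the measured compounds named here, no measured pair shows this exact exchange, so the expectation rests on the small size of the change alone. A modest step, if any, is expected: the step from compound 1 to compound 3 is estimated as a 1.6-fold lower number from compound 1 to compound 3 (0.20 log units; within the scatter), pointing toward a somewhat lower number but close to the scatter. Compound 3 is therefore expected to give about 4000 nM, within a range from 1500 nM to 12000 nM.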

Compound 3, half-maximal inhibitory concentration: 1600 nM
Compound 3: the middle estimate sits 2.5-fold (0.40 log units) above what was measured; measured number inside the range.
By their numbers in this assay, from the lowest: compound 2; then compound 3; then compound 1.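

In this assay, the group on this carbonyl carbon clearly matters: putting ethoxy in place of amino gives a 3.9-fold lower number from compound 1 to compound 3 (0.60 log units; beyond the scatter). The amino group, with its hydrogen-bond donor, is therefore not required at this place for a cytotoxic effect on these cells, since the ethoxy group, which has no such donor and more heavy atoms, gives the lower number. No measurement here explains why the number falls, so the step stands as an observation only.

Among the compounds shown here, a single exchange cannot show whether the ethoxycarbonyl group is a special case or the first step in a trend. A carboxylic acid on the same ring, a methylamino or dimethylamino group on the carbonyl carbon, or a longer chain such as propoxy or butoxy in place of ethoxy would help to separate the loss of the amide hydrogen from the gain of the added carbon chain.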